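Ethyl Biaryl Esters: Adding a Methyl Beside the Amine

This account rests on a few compounds, and the source may have more. Where it says the series, first, only, none or still open, it means among the compounds named here.

Measured compounds:
compound 1, `CCOC(=O)c1cccc(-c2ccc(OC)cc2)c1`, 80000 nM
compound 2, `CCOC(=O)c1cccc(-c2ccc(CN(C)C)cc2)c1`, 150000 nM

Two ethyl esters of the shared core have been tested in an assay on COS-7 cells for inhibition of patatin-like phospholipase domain-containing protein 2 (Mus musculus); a lower number here means a stronger inhibitor, a higher number a weaker inhibitor. Compound 1 carries a methoxy on its aromatic carbon and gives 80000 nM. Compound 2 carries (dimethylamino)methyl in the same place and gives 150000 nM. Of the two numbers, compound 2 stands at the end reached by a 1.9-fold higher number from compound 1 to compound 2 (0.27 log units; within the scatter), so the two compounds sit together within the scatter, and neither can be called the weaker or stronger.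

Compound 3, `CCOC(=O)c1cccc(-c2ccc(C(C)N(C)C)cc2)c1`, is the next step from compound 2: methyl in place of hydrogen on a saturated chain carbon bound to an amine nitrogen and an aromatic carbon. Among the measured compounds shown here, the only step that bears on this change is the one from compound 1 to compound 2, which reworked the same substituent and stayed within the scatter. Compound 3 is therefore expected to remain close to compound 2, with no change at the digits printed from compound 2 to compound 3 (within the scatter), that is no step beyond the scatter in either direction. For compound 3 in this assay the estimate is 150000 nM, with a range from 50000 nM to 450000 nM.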

Compound 3, half-maximal inhibitory concentration: 200000 nM
The estimate for compound 3 lay 1.3-fold (0.12 log units) below the measured number; low and high end bracket the measured number.
By their numbers in this assay, from the lowest: compounds 1, 2 and 3 (each within the scatter of the next, the first and the last beyond it).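

In this assay, methyl in place of hydrogen on a saturated chain carbon bound to an amine nitrogen and an aromatic carbon gives a 1.3-fold higher number from compound 2 to compound 3 (0.12 log units; within the scatter), so at this place the added methyl leaves compound 3 and compound 2 together, with no readable difference. The comparison with the methoxy compound now reads differently: the data give a 2.5-fold higher number from compound 1 to compound 3 (0.40 log units; beyond the scatter), the only step among these compounds that lies beyond the scatter, though it is modest, whereas (dimethylamino)methyl in the same place stayed within it. Nothing measured here offers an explanation for either step.

The compounds shown leave open whether an ethyl or a cyclopropyl group on the same chain carbon would carry the number beyond the scatter from compound 2, or would stay with it as methyl does. They also leave open how a primary amine or a pyrrolidine in place of the dimethylamino group would read, and whether a carboxylic acid in place of the ethyl ester would shift the whole series.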